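This account rests on a few compounds, and the source may have more. Where it says the series, first, only, none or still open, it means among the compounds named here.

Compound 1 `C=C(C)CCC[C@]1(C)C2=CCC[C@](C)(C[C@@H](O)c3ccoc3)[C@H]2CC[C@H]1C` gives 31200 nM in a functional assay on HL-60 cells (Homo sapiens) for antiproliferative activity, read by XTT assay, with a stated time of 72 h; a higher number here means a weaker inhibitor, a lower number a stronger inhibitor.
Compound 2 `C=C(C)CCC[C@]1(C)C2=CCC[C@](C)(CC(=O)c3ccoc3)[C@H]2CC[C@H]1C` gives > 100000 nM in this assay.
Compound 3 `C=C(C)CC[C@]1(C)C2=CCC[C@](C)(C[C@@H](O)c3ccoc3)[C@H]2CC[C@H]1C` gives 28700 nM in this assay.

Compound 2 stands at a limit of this assay, not at a number; its result is the limit of > 100000 nM in this assay, at which 1 of the 3 values shown sits. Compound 4 `C=C(C)CCC[C@]1(C)C2=CCC[C@](C)(C[C@H](O)c3ccoc3)[C@H]2CC[C@H]1C` has not yet been measured. It differs from compound 2 in one place: (furan-3-yl)(hydroxy)methyl in place of (furan-3-yl)carbonyl on a saturated chain carbon bound to a saturated ring carbon. For the measured compounds named here, the one measured step that bears on this change runs the other way: an at least 3.2-fold higher number from compound 1 to compound 2 (0.50 log units; beyond the scatter), where the hydroxyl-bearing carbon was turned into a carbonyl. The present change reverses that and so should give a lower number in this assay, a drop of at least modest size. The step of a 1.1-fold lower number from compound 1 to compound 3 (0.04 log units; within the scatter) concerns a different part of the molecule and gives no further guidance. Going by the values given here, compound 1 and compound 4 share the same groups and differ only in the defined stereocentre of the (furan-3-yl)(hydroxy)methyl group, and no measured pair shows how that alone matters. The expected step is an at least 2.8-fold lower number from compound 2 to compound 4 (0.45 log units; beyond the scatter). Compound 4 is therefore estimated at 35000 nM, within a range from 15000 nM to 100000 nM.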

Compound 4, half-maximal inhibitory concentration: 31200 nM
Beside the measured number, compound 4's estimate is 1.1-fold (0.05 log units) above it; low and high end bracket the measured number.
By their numbers in this assay, from the lowest: compounds 3, 1 and 4 (each within the scatter of the next). At a limit, above all of these: compound 2.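

Compound 2 is a limit of the assay, not a number: the limit of > 100000 nM in this assay, at which 1 of the 4 values shown sits. Even so, the hydroxyl form in its second drawn configuration also comes back from that limit, with an at least 3.2-fold lower number from compound 2 to compound 4 (0.50 log units; beyond the scatter), so the step seen earlier with compound 1 is not tied to one configuration at this carbon. The configuration alone changes nothing that can be read in this assay, with no change at the digits printed from compound 1 to compound 4 (within the scatter), and the comparison is a clean one: the fact that compounds 1 and 4 differ only in the configuration as drawn.

The compounds shown carry only a hydroxyl or a carbonyl at this carbon, so they leave open how an amine or a methyl ether there would read. They also leave open whether the shorter side chain of compound 3 would behave the same way with the second configuration.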